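The source may hold more compounds than are shown below. What is called first, only, known or untested is meant among the compounds shown, and "the series" means these compounds.

Of the compounds shown here, three built on the shared core have so far been tested in a functional assay on the whole organism (strain Wister albino) for inhibition, with Rattus norvegicus as the target, read by paw edema, with stated times of 1 h and 3 h, at a dose of 50 mg/kg by the intraperitoneal route; on this read-out higher numbers stand for more inhibition at the one dose given (going by the name of the read-out) and lower numbers for less inhibition. Compound 1 `CN1C(=O)[C@@]2(c3ccccc31)N(C)C[C@@H](c1ccc(F)cc1)[C@@]21Cc2ccccc2C1=O` gives 26.9%, compound 2 `CN1C(=O)[C@@]2(c3ccccc31)N(C)C[C@@H](c1ccc(Cl)cc1)[C@@]21Cc2ccccc2C1=O` gives 9.4%, and compound 3 `CN1C(=O)[C@@]2(c3ccccc31)N(C)C[C@@H](c1cccs1)[C@@]21Cc2ccccc2C1=O` gives 9.1%, the lowest of the three numbers, although its gap to compound 2 lies within the scatter. Compound 4 `COc1ccc([C@@H]2CN(C)[C@]3(C(=O)N(C)c4ccccc43)[C@]23Cc2ccccc2C3=O)cc1` differs from compound 3 in one place: 4-methoxyphenyl in place of thiophen-2-yl on a saturated ring carbon. Among the compounds with values here, two measured steps bear on an exchange at this saturated ring carbon. The step of a number 17.8 percentage points lower from compound 1 to compound 3 (beyond the scatter) and the step of a number 0.3 percentage points lower from compound 2 to compound 3 (within the scatter) show that putting thiophen-2-yl in place of 4-fluorophenyl or 4-chlorophenyl went either way, so the reverse exchange is expected to bring anything from no change to a modest gain. Compound 4 is therefore expected to give 17%, somewhere between 6% and 30%. This estimate means an expected a number 7.9 percentage points higher from compound 3 to compound 4 (within the scatter).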

Compound 4, a percentage reported as inhibition, in the whole organism at one dose (the size of the read-out at that dose, not a potency): 3.3%
Compound 4: the middle estimate sits 13.7 percentage points above what was measured, and the stated range ends above it.
By their numbers in this assay, from the lowest: compounds 4, 3 and 2 (each within the scatter of the next); then compound 1.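

In this assay, 4-methoxyphenyl on this saturated ring carbon brings no gain over thiophen-2-yl, giving a number 5.8 percentage points lower from compound 3 to compound 4 (within the scatter), and exchanging chloro for methoxy gives a number 6.1 percentage points lower from compound 2 to compound 4 (within the scatter). Among these four compounds only the 4-fluorophenyl group of compound 1 stands apart, since exchanging its fluoro for methoxy gives a number 23.6 percentage points lower from compound 1 to compound 4 (beyond the scatter). Nothing available explains why this one group differs from the others. Still open, going by these compounds, is whether an unsubstituted phenyl ring would match compound 1 or fall with the other three. A dimethylamino group or a carboxylic acid on that ring also remains an open question.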